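Urea series against intestinal cholesterol acyltransferase

A few compounds are considered here, and "the series" means these few. Any claim that something is new, unique, unknown or untested is made for them only; others in the source may bear on it.

Measured so far:
compound 1 `CCCCCCCCCCCCCCCCCCSC(=O)Nc1c(C)cccc1C` > 10000 nM
compound 2 `CCCCCCCCCCCCCCCCCCSc1c(C)cccc1C` > 10000 nM
compound 3 `CCCCCCCC/C=C\CCCCCCCCNC(=O)Nc1c(C)cc(C)cc1C` 2900 nM

In an assay on microsomes from intestinal mucosa for inhibition of acyl-CoA:cholesterol acyltransferase (Oryctolagus cuniculus) (a lower number here means a stronger inhibitor, a higher number a weaker inhibitor), compound 1 reaches only the limit of the assay, > 10000 nM. Compound 2 likewise gives only a limit in this assay, > 10000 nM. Among the measured compounds shown here, compound 3 is the sole compound with a number, 2900 nM. The other two values shown sit at a limit, (the limit of > 10000 nM in this assay, at which 2 of the 3 values shown sit).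

Compound 4 `CCCCCCCC/C=C\CCCCCCCCNC(=O)Nc1c(C)cccc1Cl` differs from compound 3 in one place: 2-chloro-6-methylphenyl in place of 2,4,6-trimethylphenyl on an amide-type nitrogen. For the measured compounds named here, no measured step covers such a change, so the size of the step from compound 3 to compound 4 in this assay is unknown; a change not beyond the usual scatter is expected, a 1.2-fold higher number from compound 3 to compound 4 (0.08 log units; within the scatter). Compound 4 is therefore estimated at 3500 nM, within 1200 nM to 10000 nM.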

Compound 4, half-maximal inhibitory concentration: 180 nM
Estimate against measurement, compound 4: 19-fold (1.29 log units) above; the whole stated range lies above it.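

In this assay, among the compounds shown here, 2-chloro-6-methylphenyl in place of 2,4,6-trimethylphenyl on an amide-type nitrogen gives a 16-fold lower number from compound 3 to compound 4 (1.21 log units; beyond the scatter), the first step between compounds that differ in one place. This position is therefore sensitive to the choice of aryl group, and a modest exchange of substituents is enough to produce a large step. No measurement shown here explains the size of this step.

Still open, on these data alone, is how a 2,6-dichlorophenyl group would compare on this nitrogen, and whether a shorter chain on the other nitrogen would keep the gain.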